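Propyl to 4-fluorophenyl on the chain carbon: compound 4

The source may hold more compounds than are shown below. What is called first, only, known or untested is meant among the compounds shown, and "the series" means these compounds.

Three measured analogues share one core. Compound 1 `COc1cccc(Cc2cnc(CCc3ccc(-c4ccccc4C(=O)O)cc3)[nH]2)c1` gives 4120 nM in an in vitro functional assay on cells for agonist activity at Bombesin receptor subtype-3 (Homo sapiens), read by luminescence and calcium flux; a higher number here means that more compound is needed for the effect, a lower number that less compound is needed; compound 2 `Cc1cccc(Cc2cnc(CCc3ccc(-c4ccccc4C(=O)O)cc3)[nH]2)c1` gives 4310 nM; compound 3 `CCCCc1cnc(CCc2ccc(-c3ccccc3C(=O)O)cc2)[nH]1` gives 2710 nM, the lowest of the three numbers, though a 1.5-fold lower number from compound 1 to compound 3 (0.18 log units; within the scatter) and a 1.6-fold lower number from compound 2 to compound 3 (0.20 log units; within the scatter) both stay within the scatter. Compound 4 `O=C(O)c1ccccc1-c1ccc(CCc2ncc(Cc3ccc(F)cc3)[nH]2)cc1` differs from compound 3 by 4-fluorophenyl in place of propyl on a saturated chain carbon bound to an aromatic carbon. The bearing steps are the reverse swaps of an aryl for propyl at the same place, a 1.5-fold lower number from compound 1 to compound 3 (0.18 log units; within the scatter) and a 1.6-fold lower number from compound 2 to compound 3 (0.20 log units; within the scatter), neither beyond the scatter, and a 1.0-fold higher number from compound 1 to compound 2 (0.02 log units; within the scatter) shows the aryl substituent mattering little. No step beyond the scatter is therefore expected; the estimated step is a 1.3-fold higher number from compound 3 to compound 4 (0.12 log units; within the scatter). Compound 4 is expected at 3600 nM, ranging from 1500 nM to 8500 nM.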

Compound 4, half-maximal effective concentration: 1600 nM
The estimate for compound 4 lay 2.3-fold (0.35 log units) above the measured number; the measured number falls inside the stated range.
By their numbers in this assay, from the lowest: compounds 4, 3, 1 and 2 (each within the scatter of the next, the first and the last beyond it).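

In this assay, within the data shown here, the step of a 2.7-fold lower number from compound 2 to compound 4 (0.43 log units; beyond the scatter) and the step of a 2.6-fold lower number from compound 1 to compound 4 (0.41 log units; beyond the scatter) are the first at this place to pass the scatter, so the aryl groups on the chain carbon are not interchangeable here. Against propyl, 4-fluorophenyl gives only a 1.7-fold lower number from compound 3 to compound 4 (0.23 log units; within the scatter) and stays within the scatter, so swapping the chain for a ring does not by itself set compound 4 apart. Nothing on hand accounts for the gap between these aryl groups.

Open, from the compounds shown here alone, is whether unsubstituted phenyl, 3-fluorophenyl or 4-chlorophenyl would fall with compound 4 or with compound 1 and compound 2. Also open, going by these compounds, is how a chain longer than propyl would compare with compound 3.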